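The compounds below may be only part of what the source reports. "The series", "measured", "known", "first", "only" and "open" are said of these compounds alone.

The three measured compounds and their values in an assay on cells (Hepatocyte) for inhibition of glucokinase regulatory protein (Mus musculus), with stated times of 20 min and 40 min; on this read-out higher numbers stand for an effect only at larger amounts of compound and lower numbers for an effect already at smaller amounts:

compound 1 `CC#C[C@H]1CN(S(=O)(=O)c2ccc(N)nc2)CCN1c1ncc(C(C)(O)C(F)(F)F)s1`: > 12500 nM
compound 2 `CC#C[C@H]1CN(S(=O)(=O)c2ccc(N)nc2)CCN1c1ccc(C(O)(COC)C(F)(F)F)cc1`: 202 nM
compound 3 `CC#C[C@H]1CN(S(=O)(=O)c2ccc(N)nc2)CCN1c1ccc(C(O)(CC#N)C(F)(F)F)cc1`: 219 nM

Compound 1 gives only a limit in this assay; it sits at the limit of > 12500 nM in this assay, at which 1 of the 3 values shown sits, so no number is known for it. Compound 2 and compound 3 both give numbers, and the step of a 1.1-fold higher number from compound 2 to compound 3 (0.04 log units; within the scatter) shows that this exchange makes no difference beyond the scatter.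

Compound 4 `CC#C[C@H]1CN(S(=O)(=O)c2ccc(N)nc2)CCN1c1ncc(C(O)(C(F)(F)F)C(F)(F)F)s1` differs from compound 1 in one place: trifluoromethyl in place of methyl on a saturated chain carbon bound to an aromatic carbon, an oxygen on a saturated carbon and a saturated chain carbon. Within the data shown here, none of the measured steps involves this kind of exchange; the only measured step, between compound 2 and compound 3, concerns a different group, so it says nothing about the size of this change. What remains is the standing of compound 1 itself, which is only a limit. The step that the limit leaves unreadable from compound 1 to compound 4 is therefore expected to be small, with no direction that the data could support. Compound 4 is expected to give 15000 nM, within a range from 3000 nM to 60000 nM, and there is a good chance that only a limit is again reported.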

Compound 4, half-maximal effective concentration: > 12500 nM
Compound 4: only a limit was reported; the forecaster's own chance of this, stated with the estimate: 60%; the middle value is on the limit's open side.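

Among these compounds, compound 1 and compound 4 each give only a limit in this assay, so no step between them can be read: the limit of > 12500 nM in this assay, at which 2 of the 4 values shown sit.

The compounds shown leave open whether trifluoromethyl in place of methyl changes the result at all.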